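This account rests on a few compounds, and the source may have more. Where it says the series, first, only, none or still open, it means among the compounds named here.

Of the compounds shown here, two on a shared core have been tested so far in a physicochemical assay for solubility (a higher number here means a more soluble compound, a lower number a less soluble compound), and neither gave an exact number. Compound 1 `COc1cc2c(cc1OC)[C@@H](C)C(=O)N(C)C=C2` returned a limit of >= 139 ug/mL. Compound 2 `C[C@H]1C(=O)N(C)C=Cc2cc(OC(CO)CO)ccc21` also returned a limit, of >= 142 ug/mL. Compound 2 therefore stands with only a limit to its name, and the one other result available is a limit too, so the two cannot be put in order.

The next compound is compound 3 `C[C@H]1C(=O)N(C)C=Cc2cc(CN3CCCC3)ccc21`, which keeps the core and changes one group on an aromatic carbon: (pyrrolidin-1-yl)methyl in place of 2-hydroxy-1-(hydroxymethyl)ethoxy ((pyrrolidin-1-yl)methyl in place of 2-hydroxy-1-(hydroxymethyl)ethoxy on an aromatic carbon). Going by the values given here, no two measured compounds differ in just one place, so no measured step can serve as a guide. The expectation rests only on compound 2 and its limit of >= 142 ug/mL. The expected step is an at least 1.0-fold lower number from compound 2 to compound 3 (0.02 log units; that floor lies within the scatter), which would be slightly downward if it shows at all and no larger than the usual scatter. For compound 3 the estimated value in this assay is 135 ug/mL, with an expected range of 80 ug/mL to 160 ug/mL.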

Compound 3, solubility: >= 97 ug/mL
Compound 3: no number, only a limit (the forecaster's own chance of this, stated with the estimate: 60%); the middle value lies beyond the limit too.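

In this assay, going by these compounds alone, compound 2 and compound 3 each returned only a limit, not an exact number, so no step between them can be read. The compounds shown leave open where each true value lies, and whether putting (pyrrolidin-1-yl)methyl in place of 2-hydroxy-1-(hydroxymethyl)ethoxy shifts the read-out at all.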